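A few compounds are considered here, and "the series" means these few. Any claim that something is new, unique, unknown or untested is made for them only; others in the source may bear on it.

In an ADME assay on MCF7 cells (Homo sapiens) for cytotoxicity, read by MTT assay, with a stated time of 72 h (a higher number here means a weaker inhibitor of growth, a lower number a stronger inhibitor of growth), compound 1 `CCCCNC(=O)C1C(C(=O)O)[C@@H]2CC[C@H]1O2` gives 10000 nM. Compound 2 `O=C(O)C1C(C(=O)Nc2ccccc2)[C@H]2CC[C@@H]1O2` gives 10000 nM, and compound 3 `O=C(O)c1ccc(NC(=O)C2C(C(=O)O)[C@@H]3CC[C@H]2O3)cc1Cl` gives 10000 nM, so compound 1 stands level with both. Compound 4 `CCCCCCCCNC(=O)C1C(C(=O)O)[C@@H]2CC[C@H]1O2` keeps the core of compound 1 but has a longer chain on the amide: butyl in place of hydrogen on a saturated chain carbon, four bonds along the chain from an amide-type nitrogen. Put simply, butyl takes the place of hydrogen on a saturated chain carbon, four bonds along the chain from an amide-type nitrogen.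

Among the measured compounds shown here, only one measured step touches this part of the molecule. With phenyl in place of butyl on an amide-type nitrogen, it shows no change at the digits printed from compound 1 to compound 2 (within the scatter). For the measured compounds named here, that step swaps the group rather than lengthening a chain, so it is only a loose guide, and no measured pair shows what a longer chain does. In this assay, the expectation is therefore for no step beyond the scatter, although a move toward stronger growth inhibition remains possible. The expected step is a 1.3-fold lower number from compound 1 to compound 4 (0.10 log units; within the scatter). Compound 4 is estimated at 8000 nM, with an expected range of 2500 nM to 20000 nM.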

Compound 4, concentration for 50% growth inhibition: 10000 nM
Beside the measured number, compound 4's estimate is 1.3-fold (0.10 log units) below it, within the range that was stated.
By their numbers in this assay, from the lowest: compounds 1, 2, 3 and 4 (each within the scatter of the next).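

In this assay, among the compounds shown here, butyl in place of hydrogen on a saturated chain carbon, four bonds along the chain from an amide-type nitrogen, gives no change at the digits printed from compound 1 to compound 4 (within the scatter) and this is the first measured pair in which the chain on the amide grows rather than being swapped for another group. A longer chain at this place therefore joins the change from butyl to phenyl as a second kind of change on the amide side that leaves the printed number unmoved. No separate measurement bears on this result.

Going by these compounds, what an amine or a hydroxyl group at the end of the chain would do remains open, as does the effect of a still longer chain. Also open, on these data alone, is whether a methyl ester in place of the carboxylic acid on the shared core would move the number in this assay at all.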